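The source may hold more compounds than are shown below. What is called first, only, known or untested is meant among the compounds shown, and "the series" means these compounds.

Compound 1 `Cc1cc(OCCCCCCC[N+]23CCN(CC2)CC3)ccc1-n1cc(C(=O)Nc2cc(F)cc(F)c2)c(=O)c2ccc(N(C)C)nc21`: "not active" (no number reported)
Compound 2 `CN(C)c1ccc2c(=O)c(C(=O)Nc3cc(F)cc(F)c3)cn(-c3ccc(OCCCCCCC[N+]45CCN(CC4)CC5)cc3Cl)c2n1`: 80%

Among the measured compounds shown here, in an assay on LX2 cells for inhibition of COL1A1 promoter (Homo sapiens), read by a luciferase reporter, with a stated time of 24 h, tested at 50 uM (on this read-out higher numbers stand for a stronger effect at the one concentration tested and lower numbers for a weaker effect), compound 2 gives 80%, the only number in this small set. Compound 1 is reported as "not active" (no number reported), with no number attached. Compound 3 `CN(C)c1ccc2c(=O)c(C(=O)Nc3cc(F)cc(F)c3)cn(-c3ccc(OCCCCCCC[N+]45CCN(CC4)CC5)cc3F)c2n1` has not yet been tested; it differs from compound 2 by fluoro in place of chloro on an aromatic carbon. For the measured compounds named here, no measured step of this kind is available to lean on, so the expected change is small, within the usual scatter, at most a slight weakening. Compound 3 is therefore estimated at 72%, in a range from 45% to 90%, which means an expected step of a number 8 percentage points lower from compound 2 to compound 3 (within the scatter).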

Compound 3, a percentage reported as inhibition, at one concentration (the size of the read-out at that concentration, not a potency): 42.4%
The estimate for compound 3 lay 29.6 percentage points above the measured number, outside the stated range (below it).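

In this assay, fluoro in place of chloro on this aromatic carbon, ortho to a large group and meta to a large group, gives a number 37.6 percentage points lower from compound 2 to compound 3 (beyond the scatter), so exchanging one heavy atom for another, with hydrogen-bond counts and net charge unchanged, is enough to move the read-out beyond the scatter. Compound 3 still gives 42.4% as a measured number, unlike the bare "not active" entry for compound 1. No measurement shown here explains the difference between the two halogens.

From the compounds shown here alone, it remains open how a bromo, methoxy or nitrile group on this same carbon would compare with chloro and fluoro.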